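This account rests on a few compounds, and the source may have more. Where it says the series, first, only, none or still open, it means among the compounds named here.

Compound 1 `COc1ccc(N2CCN(C(=S)SCc3ccc(C(=O)Nc4ccccc4N)cc3)CC2)cc1` gives 22.9% in a functional assay on MGC-803 cells (Homo sapiens) for antiproliferative activity, read by CCK-8 assay, with a stated time of 72 h, tested at 8 uM (a lower number here means a weaker effect, a higher number a stronger effect of the compound at the concentration tested), and compound 2 `Cc1ccc(N2CCN(C(=S)SCc3ccc(C(=O)Nc4ccccc4N)cc3)CC2)cc1` gives 19.8%; compound 3 `CN(Cc1cccnc1)C(=S)SCc1ccc(C(=O)Nc2ccccc2N)cc1` gives 85.5%. Compound 2 thus has the lowest of the three numbers, lying within the scatter of compound 1 and far below compound 3.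

Compound 4 `Nc1ccccc1NC(=O)c1ccc(CSC(=S)N2CCN(c3cnccn3)CC2)cc1` differs from compound 2 by pyrazin-2-yl in place of 4-methylphenyl on an amine nitrogen in a ring. Going by the values given here, the only measured step at a related site, a number 3.1 percentage points lower from compound 1 to compound 2 (within the scatter), swaps one small group on the aromatic ring for another, whereas here the whole ring is exchanged for a ring bearing two nitrogen atoms. Compound 3 shows that a different group on this nitrogen can give a much higher number. An increase of moderate size, with wide uncertainty, is therefore expected, a number 15.2 percentage points higher from compound 2 to compound 4 (beyond the scatter). Compound 4 is estimated at 35%, in the range 12% to 72%.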

Compound 4, a percentage reported as inhibition, at one concentration (the size of the read-out at that concentration, not a potency): 80.5%
Compound 4: the middle estimate sits 45.5 percentage points below what was measured; the whole stated range lies below it.
By their numbers in this assay, from the lowest: compounds 2 and 1 (each within the scatter of the next); then compounds 4 and 3 (each within the scatter of the next).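

Exchanging the whole ring on this amine nitrogen has a far larger effect in this assay than the earlier swap of one small group: pyrazin-2-yl in place of 4-methylphenyl gives a number 60.7 percentage points higher from compound 2 to compound 4 (beyond the scatter), and in place of 4-methoxyphenyl gives a number 57.6 percentage points higher from compound 1 to compound 4 (beyond the scatter). The low numbers of the two phenyl-type compounds therefore do not hold for every aromatic ring at this position. No evidence here explains the rise. The compounds shown leave open whether the gain follows the ring nitrogens or the missing methyl or methoxy group. Plain phenyl and pyridin-2-yl at this position would help separate those two readings.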